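A Single Swap at the Edge of a Shared Core

The compounds below may be only part of what the source reports. "The series", "measured", "known", "first", "only" and "open" are said of these compounds alone.

Of the compounds shown here, three of one chemical family have been tested in a functional assay on DU-145 cells (Homo sapiens) for inhibition, read by trypan blue exclusion, with a stated time of 96 h; a lower number here means a stronger inhibitor of growth, a higher number a weaker inhibitor of growth. Compound 2 `O=C(O)c1ccc(C(=O)/C(=C\c2ccc(Br)cc2)SCc2ccc(Br)cc2)cc1` gives 1000 nM, the lowest of the three numbers. Compound 3 `CSc1ccc(/C=C(\C(=O)c2ccc(Br)cc2)S(=O)(=O)Cc2ccc(C)cc2)cc1` gives 10000 nM, a number higher than that of compound 2 and beyond the usual scatter. Compound 1 `CCOc1ccc(/C=C(\C(=O)c2ccc(Cl)cc2)S(=O)(=O)Cc2ccc(F)cc2)cc1OC` gives 50000 nM, the highest of the three and the furthest from compound 2. On these numbers compound 2 is therefore the strongest inhibitor of growth among the measured compounds.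

Compound 4 `CN(C)c1ccc(/C=C(/SCc2ccc(Br)cc2)C(=O)c2ccc(C(=O)O)cc2)cc1` has not yet been measured. It keeps the core of compound 2 and differs from it in one place: dimethylamino in place of bromo on an aromatic carbon. The group that leaves and the group that enters sit on the same aromatic carbon of a six-membered aromatic ring of carbon only.

Among the compounds with values here, no pair among the measured compounds differs in just this way, so there is no measured step to lean on. The expectation is therefore cautious: the step of a 1.5-fold higher number from compound 2 to compound 4 (0.18 log units; within the scatter) is expected to be small, perhaps within the scatter of repeated measurement, with a slight lean toward a weaker inhibitor. Compound 4 is expected to give about 1500 nM, within a range from 300 nM to 8000 nM in this assay.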

Compound 4, concentration for 50% growth inhibition: 50000 nM
For compound 4 the middle estimate is 33-fold (1.52 log units) below the measured one; the whole stated range lies below it.
By their numbers in this assay, from the lowest: compound 2; then compound 3; then compounds 1 and 4 (each within the scatter of the next).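

Replacing bromo with dimethylamino on this aromatic carbon, para to a large group, gives a 50-fold higher number from compound 2 to compound 4 (1.70 log units; beyond the scatter) in this assay, so a change in one place takes compound 2 from the strongest inhibitor of growth measured to a far weaker one. The earlier compounds shown here differ from one another in several places at once and could not tie a change in number to any single site, whereas this pair shows that the group at this position can matter a great deal. No measurement available here bears on why this swap has so large an effect.

On these data alone, with only bromo and dimethylamino compared at this carbon, it remains open whether a plain amino group or a nitrile there would give a number close to that of compound 2 or close to that of compound 4. As far as these compounds go, it is also open whether the same swap would produce a step of similar size in a compound carrying the sulfonyl group of compound 3 in place of the sulfur link of compound 2.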